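The source may hold more compounds than are shown below. What is called first, only, known or untested is meant among the compounds shown, and "the series" means these compounds.

Of the compounds shown here, three built on a shared core have been measured in a functional assay on DU-145 cells (Homo sapiens) for antiproliferative activity, read by MTT assay, with a stated time of 24 h; a lower number here means a stronger inhibitor, a higher number a weaker inhibitor. Compound 1 `COc1ccc(/C=C/C(=O)c2cc(-c3ccc(OC)c(OC)c3)n3nc(-c4ccccc4)cc3n2)cc1` gives 14900 nM in this assay, compound 2 `COc1ccc(-c2cc(/C=C/C(=O)c3ccc(C)cc3)nc3cc(-c4ccccc4)nn23)cc1OC` gives 26800 nM, and compound 3 `COc1ccc(C(=O)/C=C/c2cc(-c3ccc(OC)c(OC)c3)n3nc(-c4ccccc4)cc3n2)cc1` gives 14600 nM. Among these three numbers compound 1 holds the second highest, with compound 3 nearest and compound 2 furthest, yet both a 1.0-fold lower number from compound 1 to compound 3 (0.01 log units; within the scatter) and a 1.8-fold higher number from compound 1 to compound 2 (0.25 log units; within the scatter) stay within the scatter, so the three compounds cannot be placed in any order.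

Compound 4 `COc1ccc(/C=C/C(=O)c2cc(-c3cc(OC)c(OC)c(OC)c3)n3nc(-c4ccccc4)cc3n2)cc1` is the next compound, and it differs from compound 1 in one place: methoxy in place of hydrogen on an aromatic carbon. Among the measured compounds shown here, none of the measured steps makes this change. The closest is a 1.8-fold lower number from compound 2 to compound 3 (0.26 log units; within the scatter), which also concerns a methoxy group, though at another place in the molecule; it lies within the scatter, as do the two steps that rearrange the linking chain. For the measured compounds named here, with no measured step that bears on the change, and no step of any size beyond the scatter in the whole set, the number for compound 4 is expected to lie close to that of compound 1. The expected step is a 1.0-fold higher number from compound 1 to compound 4 (0.00 log units; within the scatter), within the scatter. Compound 4 is therefore estimated at 15000 nM, within a range from 6500 nM to 35000 nM.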

Compound 4, half-maximal inhibitory concentration: 16900 nM
Estimate against measurement, compound 4: 1.1-fold (0.05 log units) below; measured number inside the range.
By their numbers in this assay, from the lowest: compounds 3, 1, 4 and 2 (each within the scatter of the next).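

Among the compounds shown here, the step from 3,4-dimethoxyphenyl to 3,4,5-trimethoxyphenyl is the first measured change on this ring, since compounds 1, 2 and 3 all carry the same 3,4-dimethoxyphenyl group and differ only in the linking chain and in the group at its far end. In this assay it amounts to a 1.1-fold higher number from compound 1 to compound 4 (0.05 log units; within the scatter), so a methoxy group at this place, ortho to one methoxy group and meta to another, cannot be told apart from hydrogen in this read-out, and the ring now joins the linking chain as a part of the molecule where the measured steps all stay within the scatter. No measurement is available that bears on why this number stays where it does.

The compounds shown leave open whether a different group at this same place, such as a hydroxy group, a fluorine atom or an amine, would produce a step beyond the scatter. They also leave open whether the 3,4,5-trimethoxyphenyl group would give the same result when paired with the linking chains of compound 2 or compound 3.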